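A benzyl swap at the limit of the assay

A few compounds are considered here, and "the series" means these few. Any claim that something is new, unique, unknown or untested is made for them only; others in the source may bear on it.

Values in a functional assay on HUVEC cells (Homo sapiens) for inhibition, with stated times of 2 h and 72 h (a lower number here means a stronger inhibitor, a higher number a weaker inhibitor), each one a limit and not a number:
compound 1 `COc1cc2nccc(Oc3ccc4c(NC(=O)c5cccc(C)c5)nn(C)c4c3)c2cc1OC`: > 1000 nM
compound 2 `COc1ccc(Nc2nn(C)c3cc(Oc4ccnc5cc(OC)c(OC)cc45)ccc23)cc1`: > 1000 nM
compound 3 `COc1cc2nccc(Oc3ccc4c(NC(=O)Nc5ccc(C)cc5)nn(C)c4c3)c2cc1OC`: > 1000 nM

Compound 3 has no exact value and stands at the limit of > 1000 nM in this assay, at which 3 of the 3 values shown sit. The next compound, compound 4 `COc1cc2nccc(Oc3ccc4c(NCc5ccccc5)nn(C)c4c3)c2cc1OC`, differs from it in one place: benzyl in place of (4-methylphenyl)carbamoyl on a nitrogen on an aromatic ring. In words, benzyl takes the place of (4-methylphenyl)carbamoyl on a nitrogen on an aromatic ring.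

The closest measured change is a step that the two limits leave unreadable from compound 2 to compound 3, at this same nitrogen. Two more changes at that nitrogen are a step that the two limits leave unreadable from compound 1 to compound 2 and a step that the two limits leave unreadable from compound 1 to compound 3. None of these gives a size, so the steps cannot set the expectation by themselves. Still, compound 1, compound 2 and compound 3 carry different groups on that nitrogen, and none of them gave a number in this assay. Compound 2 also has no carbonyl on that nitrogen, and its value is the limit > 1000 nM.

No clear step is therefore expected in this assay, and compound 4 will most likely also be reported only as a limit. The expected size is a step that the limit leaves unreadable from compound 3 to compound 4, with no firm direction. For compound 4, the estimated value is 2000 nM, with an expected range from 500 nM to 10000 nM.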

Compound 4, half-maximal inhibitory concentration: > 1000 nM
Compound 4 ended at the assay's limit; the forecaster's own chance of this, stated with the estimate: 75%; the middle value is on the limit's open side.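

In this assay compound 4 gives > 1000 nM, which is a limit and not a number. The steps to compound 4 from compound 1, compound 2 and compound 3 cannot be read. The compounds shown leave open how strongly each one inhibits and whether the group on that nitrogen changes this at all: the limit of > 1000 nM in this assay, at which 4 of the 4 values shown sit.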